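A few compounds are considered here, and "the series" means these few. Any claim that something is new, unique, unknown or untested is made for them only; others in the source may bear on it.

Compound 1 `COCCNc1nc(C)nc2c1nnn2-c1c(C)cc(C)cc1C`: 1200 nM in an in vitro assay on 293-EBNA cells for binding affinity to corticotropin-releasing factor receptor 1 (Homo sapiens); on this read-out lower numbers stand for stronger inhibition and higher numbers for weaker inhibition.
Compound 2 `COCC(COC)N(C)c1nc(C)nc2c1nnn2-c1ccc(C(C)C)cc1Br`: 21.3 nM in this assay.
Compound 3 `CCN(c1nc(C)nc2c1nnn2-c1ccc(C(C)C)cc1Br)C(COC)COC`: 123 nM in this assay.

Compound 3 holds the second highest of the three numbers; compound 2 lies nearer to it than compound 1. Compound 4 `COCCCNc1nc(C)nc2c1nnn2-c1ccc(C(C)C)cc1Br` carries a group of 6 heavy atoms (4 carbon, 1 nitrogen, 1 oxygen; no ring) in place of a group of 10 heavy atoms (7 carbon, 1 nitrogen, 2 oxygen; no ring), on an aromatic carbon. Among the measured compounds shown here, the only measured step at this position is a 5.8-fold higher number from compound 2 to compound 3 (0.76 log units; beyond the scatter), which shows that the amine substituent does move the numbers in this assay. For the measured compounds named here, compound 1, bearing a short methoxy-terminated chain on a different aryl group, gives the highest number, but no single-place step links it to compound 4. A modest shift is therefore expected for compound 4, a 1.2-fold higher number from compound 3 to compound 4 (0.09 log units; within the scatter), with wide uncertainty. The estimate for compound 4 is 150 nM, range 40 nM to 600 nM.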

Compound 4, inhibition constant: 291 nM
Compound 4: middle estimate off by 1.9-fold (0.29 log units), on the low side, and the stated range covers the measured number.
By their numbers in this assay, from the lowest: compound 2; then compound 3; then compound 4; then compound 1.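

At this aromatic carbon, (3-methoxypropyl)amino raises the number in this assay with a 2.4-fold higher number from compound 3 to compound 4 (0.37 log units; beyond the scatter) and with a 14-fold higher number from compound 2 to compound 4 (1.14 log units; beyond the scatter) as the larger step. Earlier compounds showed only a methyl-for-hydrogen change on the chain, whereas this exchange replaces the whole group and adds a hydrogen-bond donor. No measurement here accounts for the rise.

The compounds shown do not separate the effect of that donor from the effect of the smaller, unbranched chain. A methylated amine carrying the same 3-methoxypropyl chain, or a longer ether chain, would address that question.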